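Chloro for Fluoro on the Aryl Ring of Compound 2

The compounds below may be only part of what the source reports. "The series", "measured", "known", "first", "only" and "open" are said of these compounds alone.

Of the compounds shown here, two have been measured in a functional assay on HEK293 cells for positive allosteric modulation of metabotropic glutamate receptor 5 (Homo sapiens), read by FLIPR and calcium flux; on this read-out higher numbers stand for an effect only at larger amounts of compound and lower numbers for an effect already at smaller amounts. Compound 1 `O=C(COCc1ccccc1)N1CCN(c2cccc(Cl)c2)CC1` gives 6700 nM, while compound 2 `O=C(COCc1ccncc1)N1CCC(c2ccc(F)cc2Cl)CC1` gives 370 nM; compound 2 thus holds the lower of the two numbers, and its gap to compound 1 lies beyond the usual scatter. Compound 3 `O=C(COCc1ccncc1)N1CCC(c2ccc(Cl)cc2Cl)CC1` is compound 2 with a single change: chloro in place of fluoro on an aromatic carbon. Going by the values given here, no two measured compounds differ in only one place, so the size of such a step is not known here. The step is expected to be small and toward a slightly lower number: a 1.5-fold lower number from compound 2 to compound 3 (0.17 log units; within the scatter). Compound 3 is therefore estimated at 250 nM, with a likely range from 80 nM to 800 nM.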

Compound 3, half-maximal effective concentration: 390 nM
Beside the measured number, compound 3's estimate is 1.6-fold (0.19 log units) below it; the range from low to high includes it.
By their numbers in this assay, from the lowest: compounds 2 and 3 (each within the scatter of the next); then compound 1.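

In this assay, chloro in place of fluoro on this aromatic carbon gives a 1.1-fold higher number from compound 2 to compound 3 (0.02 log units; within the scatter) as the first single-change step available in this series. That step lies within the scatter, so the 2-chloro-4-fluorophenyl and 2,4-dichlorophenyl compounds cannot be told apart here, and this position accepts either halogen without a readable change. Nothing measured here gives a reason for this. Going by these compounds, what a plain hydrogen, a methoxy group or a nitrile would do at this position remains open, so the tolerance seen here is known only for these two halogens.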